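The source may report more compounds than this note shows. Statements on the series, on what has been measured and on what is new or still open speak of the compounds shown alone.

Measured so far:
- compound 1, `C[C@@H](NC(=O)[C@H](CC(=O)O)NC(=O)CNC(=O)c1cccc(NC(=N)N)c1)c1ccccc1`: 45 nM
- compound 2, `C[C@H](NC(=O)[C@H](CC(=O)O)NC(=O)CNC(=O)c1cccc(NC(=N)N)c1)c1ccccc1`: 20 nM

Both compounds were read in an assay on a protein complex for binding affinity to integrin alpha-5/beta-1 (Homo sapiens), read by ELISA, with a stated time of 1 h; on this read-out higher numbers stand for weaker inhibition and lower numbers for stronger inhibition. Compound 1 gives 45 nM and compound 2 gives 20 nM; compound 2 therefore holds the lower of the two numbers, with compound 1 the nearest at a gap that is beyond the scatter. Going by the values given here, the one measured step, a 2.3-fold lower number from compound 1 to compound 2 (0.35 log units; beyond the scatter), rests on a single stereocentre at the saturated chain carbon of the 1-phenylethyl group (the fact that one of compounds 1 and 2 is drawn with a defined configuration and the other without, at the place where they differ).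

Compound 3, `N=C(N)Nc1cccc(C(=O)NCC(=O)N[C@@H](CC(=O)O)C(=O)NCc2ccc(Cl)cc2)c1`, is not yet measured. It differs from compound 2 by 4-chlorobenzyl in place of 1-phenylethyl on an amide-type nitrogen. Among the compounds with values here, no measured step bears directly on this change: the only step in hand concerns the configuration at the chain carbon, and in compound 3 that carbon and its stereocentre are gone, so the modest size of a 2.3-fold lower number from compound 1 to compound 2 (0.35 log units; beyond the scatter) is the only guide to how much this part of the molecule moves the number. The expectation for compound 3 is a small step, a 2.0-fold higher number from compound 2 to compound 3 (0.30 log units; within the scatter), in either direction within or near the scatter. Compound 3 is estimated at 40 nM in this assay, with a range of 15 nM to 120 nM.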

Compound 3, half-maximal inhibitory concentration: 48 nM
For compound 3 the middle estimate is 1.2-fold (0.08 log units) below the measured one, within the range that was stated.
By their numbers in this assay, from the lowest: compound 2; then compounds 1 and 3 (each within the scatter of the next).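

In this assay the meaning of this exchange depends on which 1-phenylethyl compound it is read from: from the S-drawn form it is a real loss (a 2.4-fold higher number from compound 2 to compound 3 (0.38 log units; beyond the scatter)), while from the R-drawn form it changes nothing that can be told apart (a 1.1-fold higher number from compound 1 to compound 3 (0.03 log units; within the scatter)). The 4-chlorobenzyl group, which has no stereocentre at this place, is therefore tolerated on the amide-type nitrogen about as well as the R-drawn 1-phenylethyl group, and among these three only compound 2 stands apart, with its steps to both others beyond the scatter. Nothing in hand gives a cause for the new steps.

The compounds shown do not separate the chlorine from the change at the chain carbon, as both differ at once between compound 2 and compound 3. A plain benzyl group on this nitrogen would bear on that split, and a longer chain such as 2-phenylethyl would show whether the distance from the nitrogen to the ring matters here.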